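The source may hold more compounds than are shown below. What is called first, only, known or untested is meant among the compounds shown, and "the series" means these compounds.

Of the compounds shown here, two from this series have been measured so far. Compound 1, with the structure `O=C1C(=O)N(Cc2ccc(-c3cccnc3)cc2)c2ccc(OC(F)(F)F)cc21`, and compound 2, with the structure `O=C1C(=O)N(Cc2ccc(-c3ccccc3)cc2F)c2ccc(OC(F)(F)F)cc21`, share the same core and differ only in the group hanging from the benzyl arm. In a functional assay on CHO cells for positive allosteric modulation of muscarinic acetylcholine receptor M5 (Homo sapiens), read by FLIPR and calcium flux, with a stated time of 1 h (on this read-out lower numbers stand for smaller maximal responses and higher numbers for larger maximal responses), compound 1 gives 51%, which is the lower of the two numbers; compound 2 gives 63%, a number that lies beyond the usual scatter above compound 1.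

Compound 3, with the structure `O=C1C(=O)N(Cc2ccc(Oc3cccc(F)n3)cc2)c2ccc(OC(F)(F)F)cc21`, has not yet been measured. It is derived from compound 1 by a single change: (6-fluoropyridin-2-yl)oxy in place of pyridin-3-yl on an aromatic carbon. Going by the values given here, no pair of measured compounds shows a step of this kind, so there is no direct guide to how large the effect should be. Among the compounds with values here, the only information is that a change at this same aromatic carbon, between compound 1 and compound 2, moved the read-out modestly.

For compound 3 the expected step of a number 4 percentage points higher from compound 1 to compound 3 (within the scatter) is therefore small and of uncertain direction, at most a little upward. Compound 3 is estimated to give 55% in this assay, with a plausible range from 35% to 75%.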

Compound 3, largest response reached (Emax), in percent of the reference or control that the assay uses: 62%
Beside the measured number, compound 3's estimate is 7 percentage points below it, and the stated range covers the measured number.
By their numbers in this assay, from the lowest: compound 1; then compounds 3 and 2 (each within the scatter of the next).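

In this assay, going by these compounds alone, swapping pyridin-3-yl for (6-fluoropyridin-2-yl)oxy on the aromatic carbon para to a large group gives a number 11 percentage points higher from compound 1 to compound 3 (beyond the scatter), the first step at this position that can be read as a single change. It shows that this position can carry a larger group, with its ring attached through an oxygen and bearing a fluorine, and that the maximal response rises modestly rather than falling. The change alters the link, the ring attachment point and the fluorine at once, and nothing measured here explains the rise or assigns it to any one of these parts.

As far as these compounds go, it remains open which of these parts matters: a (pyridin-2-yl)oxy group without the fluorine, or a (6-fluoropyridin-2-yl)amino group with an amine link in place of the oxygen, would pull them apart. From the compounds shown here alone, it is equally open how the response would move with a simple phenoxy group or a longer chain, such as a benzyloxy group, at this same carbon.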